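Methoxy to chloro exchange on compound 1

The compounds below may be only part of what the source reports. "The series", "measured", "known", "first", "only" and "open" are said of these compounds alone.

For the measured compounds named here, compound 1 `COc1ccc(Cc2c(C)[nH]n(-c3nc4ccccc4[nH]3)c2=O)cc1` is the only member of the series with a numeric result: in an assay on isolated protein for inhibition of alpha-ketoglutarate-dependent dioxygenase alkB homolog 3 (Homo sapiens), read by polymerase chain reaction, with a stated time of 1 h (a higher number here means a weaker inhibitor, a lower number a stronger inhibitor), compound 1 gives 630 nM. The other measured compound, compound 2 `O=c1c(Cc2ccccc2)c(-c2ccccc2)[nH]n1-c1nc2ccccc2[nH]1`, does not give a number. In this assay compound 2 gives > 10000 nM, which is a limit of the assay and not a number. Going by the values given here, of the two values shown, one sits at the limit of > 10000 nM in this assay, at which 1 of the 2 values shown sits, so no step between measured compounds can be sized, and the standing of compound 1 rests on its single number alone.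

Compound 3 `Cc1[nH]n(-c2nc3ccccc3[nH]2)c(=O)c1Cc1ccc(Cl)cc1` differs from compound 1 in one place: chloro in place of methoxy on an aromatic carbon. Among the compounds with values here, no measured pair shows this exchange, so nothing sized bears on it; the estimate below is a plain expectation. The expected step of a 1.3-fold higher number from compound 1 to compound 3 (0.10 log units; within the scatter) in this assay is no larger than the scatter of repeated measurements, in either direction. Compound 3 is therefore estimated at 800 nM in this assay, with a range of 250 nM to 3000 nM.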

Compound 3, half-maximal inhibitory concentration: > 10000 nM
Compound 3 ended at the assay's limit; the forecaster's own chance of this, stated with the estimate: 10%; middle value at least 12-fold (1.09 log units) from the limit.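

For the compounds shown here, the position on the six-membered aromatic ring of carbon only, para to a large group, is not indifferent to what it carries: in this assay, chloro in place of methoxy gives an at least 15-fold higher number from compound 1 to compound 3 (1.20 log units; beyond the scatter), the first step that can be sized and one that lies beyond the scatter. From the compounds shown here alone, compound 3 gives > 10000 nM, which is a limit of the assay and not a number, so the step has a lower bound only and its full size stays unknown. Compound 1 remains the only compound with a numeric result, and readings at the limit now make up most of the series: the limit of > 10000 nM in this assay, at which 2 of the 3 values shown sit.

The compounds shown do not separate the loss of the methoxy, with the hydrogen-bond acceptor counted on it, from the entry of chloro; a hydroxy, an ethoxy, a methyl or a fluoro in the same place would bear on that. Also open, going by these compounds, is whether any group in this place gives a lower number than compound 1 does, and whether an amine or a longer chain is accepted there at all.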